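Notes on extending the chain of compound 1

A few compounds are considered here, and "the series" means these few. Any claim that something is new, unique, unknown or untested is made for them only; others in the source may bear on it.

Measured in a functional assay on MCF7 cells (Homo sapiens) for cytotoxicity; a lower number here means a stronger inhibitor, a higher number a weaker inhibitor:
- compound 1 `COc1ccc2nc(NC(=O)CCCCC(=O)NO)sc2c1`: 5.91 ug/mL
- compound 2 `Cc1ccc2nc(NC(=O)CCCCC(=O)NO)sc2c1`: 4.27 ug/mL

Compound 1 holds the higher of the two numbers, but the gap does not separate them: a 1.4-fold lower number from compound 1 to compound 2 (0.14 log units; within the scatter). Compound 3 `COc1ccc2nc(NC(=O)CCCCCCC(=O)NO)sc2c1` is the next to be read, with this change: 2-(hydroxycarbamoyl)ethyl in place of hydroxycarbamoyl on a saturated chain carbon, four bonds along the chain from a carbonyl carbon. That single measured step, methyl in place of methoxy on an aromatic carbon, leaves the chain untouched, so it gives no measured size for this change. No step beyond the scatter is therefore expected, and the expected step is a 1.3-fold lower number from compound 1 to compound 3 (0.12 log units; within the scatter). For compound 3 the estimate is 4.5 ug/mL, with an expected range of 1.5 ug/mL to 12 ug/mL.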

Compound 3, half-maximal inhibitory concentration: 1.85 ug/mL
Compound 3: middle estimate off by 2.4-fold (0.39 log units), on the high side; the range from low to high includes it.
By their numbers in this assay, from the lowest: compound 3; then compounds 2 and 1 (each within the scatter of the next).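

In this assay, within the data shown here, the length of the chain matters at this position: 2-(hydroxycarbamoyl)ethyl in place of hydroxycarbamoyl gives a 3.2-fold lower number from compound 1 to compound 3 (0.50 log units; beyond the scatter) and is the first step to pass the scatter. Among these compounds, the aromatic-carbon step left the chain unchanged, so only this step gives a measured size for the extension. No available evidence bears on the reason for this step.

A longer chain, such as one ending in 4-(hydroxycarbamoyl)butyl, could extend the gain or reverse it. Also open, going by these compounds, is whether a carboxylic acid could replace the terminal hydroxycarbamoyl group on the extended chain.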